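A few compounds are considered here, and "the series" means these few. Any claim that something is new, unique, unknown or untested is made for them only; others in the source may bear on it.

Compound 1 `COc1cc(-c2ccnc3cc(-c4ccc(Cl)cc4)nn23)cc(OC)c1OC`: 1490 nM
Compound 2 `COc1cc(-c2ccnc3c(-c4ccc(C)cc4)cnn23)cc(OC)c1OC`: > 10000 nM

Two compounds carry results in a functional assay on HeLa cells (Homo sapiens) for inhibition, read by CCK-8 assay, with a stated time of 48 h; a lower number here means a stronger inhibitor, a higher number a weaker inhibitor. Compound 1 gives 1490 nM, and this is the only plain number shown. For compound 2 the result is a limit of the assay rather than a number, namely (the limit of > 10000 nM in this assay, at which 1 of the 2 values shown sits). Compound 3 `COc1cc(-c2ccnc3cc(-c4ccc5ccn(C)c5c4)nn23)cc(OC)c1OC` has not yet been measured. It differs from compound 1 in one place: 1-methyl-1H-indol-6-yl in place of 4-chlorophenyl on an aromatic carbon. For the measured compounds named here, no step between two measured compounds is available to gauge what such a change does in this assay, so the expectation rests on compound 1 alone and is wide. The expected step is a 1.2-fold lower number from compound 1 to compound 3 (0.09 log units; within the scatter), that is, essentially none beyond the usual scatter, with no clear direction. Compound 3 is estimated to give 1200 nM, with a range from 300 nM to 5000 nM.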

Compound 3, half-maximal inhibitory concentration: 187 nM
Beside the measured number, compound 3's estimate is 6.4-fold (0.81 log units) above it, outside the stated range (below it).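

In this assay, the group on an aromatic carbon of the five-membered aromatic ring with 2 nitrogen proves open to change, with 1-methyl-1H-indol-6-yl in place of 4-chlorophenyl giving an 8.0-fold lower number from compound 1 to compound 3 (0.90 log units; beyond the scatter). For the compounds shown here, this is the first step readable at this place, and it shows that a larger group of two fused aromatic rings, carrying a ring nitrogen, is accepted there and gives the stronger inhibitor of the pair. No measurement shown gives a cause for this step.

The compounds shown leave open whether the change in number follows the second ring, the ring nitrogen or its methyl, which a naphthalen-2-yl group or the 1H-indol-6-yl group could separate. They also leave open how an amine or a carboxylic acid on the indole would fare.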